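Swapping the Aryl Ether on a Thromboxane Synthase Inhibitor Core

The source may report more compounds than this note shows. Statements on the series, on what has been measured and on what is new or still open speak of the compounds shown alone.

Of the compounds shown here, three have been measured in an assay for inhibition of Thromboxane-A synthase (Homo sapiens), using microsomes; on this read-out higher numbers stand for weaker inhibition and lower numbers for stronger inhibition. Compound 1 `O=C(O)CC/C=C\CC1COC(c2ccc([N+](=O)[O-])cc2)OC1c1cccnc1` gives 39 nM. Compound 2 `Cc1ccc(C#N)c(OC(C)(C)C2OCC(C/C=C\CCC(=O)O)C(c3cccnc3)O2)c1` gives 50 nM in this assay. Compound 3 `COc1ccccc1OC(C)(C)C1OCC(C/C=C\CCC(=O)O)C(c2cccnc2)O1` gives 60 nM in this assay, which is the highest of the three numbers, although its gaps to compound 2 and to compound 1 both fall within the scatter of repeated measurements, so the three compounds cannot be told apart by these data.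

Compound 4 `CC(C)(Oc1ccc(F)cc1[N+](=O)[O-])C1OCC(C/C=C\CCC(=O)O)C(c2cccnc2)O1` differs from compound 3 in one place: 4-fluoro-2-nitrophenyl in place of 2-methoxyphenyl on an oxygen on a saturated carbon. Among the measured compounds shown here, one measured step bears on this kind of change, an exchange of the aromatic group sitting on the same oxygen: a 1.2-fold higher number from compound 2 to compound 3 (0.08 log units; within the scatter). That step stayed within the scatter, and the present change is of the same kind, so no shift beyond the scatter is expected for compound 4 in this assay. The expected step is no change at the digits printed from compound 3 to compound 4 (within the scatter). Compound 4 is therefore estimated at 60 nM in this assay, with a range from 25 nM to 150 nM.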

Compound 4, half-maximal inhibitory concentration: 20 nM
Beside the measured number, compound 4's estimate is 3.0-fold (0.48 log units) above it; measured number outside the range, below it.
By their numbers in this assay, from the lowest: compounds 4, 1, 2 and 3 (each within the scatter of the next, the first and the last beyond it).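

The aromatic group on this oxygen can move the number: in this assay, 4-fluoro-2-nitrophenyl gives a 3.0-fold lower number from compound 3 to compound 4 (0.48 log units; beyond the scatter) when it replaces 2-methoxyphenyl and a 2.5-fold lower number from compound 2 to compound 4 (0.40 log units; beyond the scatter) when it replaces 2-cyano-5-methylphenyl. Among the compounds shown here, the exchange between those two earlier groups stayed within the scatter, so these are the first steps at this place that stand beyond it, and both point to stronger inhibition. No measurement shown here explains why this group behaves differently from the other two.

Among the compounds shown, the fluorine and the nitro group occur together on this aromatic ring, so their separate contributions remain open. Also open, from the compounds shown here alone, is how an unsubstituted phenyl, or an aromatic ring bearing an amine or a carboxylic acid, would read at this place.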